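Exchanging the Acyl Group on the Ring Nitrogen

The compounds below may be only part of what the source reports. "The series", "measured", "known", "first", "only" and "open" are said of these compounds alone.

Measured so far in a functional assay on MDA-MB-231 cells (Homo sapiens) for inhibition, read by sulforhodamine B assay, tested at 10 uM; on this read-out higher numbers stand for more inhibition at the one concentration tested (going by the name of the read-out) and lower numbers for less inhibition:
compound 1 `CN(C)c1ccc(C2CC(c3ccc(-n4ccnc4)cc3)=NN2)cc1`: 7.6%
compound 2 `COC(=O)CC(=O)N1N=C(c2ccc(N3CCN(C)CC3)cc2)CC1c1ccc(N(C)C)cc1`: -0.4%
compound 3 `C=C(C)C(=O)N1N=C(c2ccc(-n3ccnc3)cc2)CC1c1ccc(N(C)C)cc1`: 4.3%

All three numbers lie within the usual scatter of one another, so compound 3 cannot be set apart from compound 1 or compound 2. Within the data shown here, the one measured step, a number 3.3 percentage points lower from compound 1 to compound 3 (within the scatter), shows that adding an acyl group to the ring nitrogen left the read-out essentially unchanged.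

Compound 4 `COC(=O)CC(=O)N1N=C(c2ccc(-n3ccnc3)cc2)CC1c1ccc(N(C)C)cc1` differs from compound 3 in one place: (methoxycarbonyl)methyl in place of 1-methylethenyl on a carbonyl carbon. Among the measured compounds shown here, no measured step covers this exact exchange. Compound 2 carries the same entering group on its carbonyl but a different aryl substituent, and its value and that of compound 3 sit within the scatter. The step of a number 1.3 percentage points lower from compound 3 to compound 4 (within the scatter) is therefore expected to stay within the scatter, with compound 4 estimated at 3%, in the range -8% to 14%.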

Compound 4, a percentage reported as inhibition, at one concentration (the size of the read-out at that concentration, not a potency): 2.3%
Compound 4: the middle estimate sits 0.7 percentage points above what was measured; the range from low to high includes it.
By their numbers in this assay, from the lowest: compounds 2, 4, 3 and 1 (each within the scatter of the next).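

In this assay, (methoxycarbonyl)methyl in place of 1-methylethenyl on the carbonyl carbon gives a number 2 percentage points lower from compound 3 to compound 4 (within the scatter) and leaves the two compounds inseparable on this read-out. Adding the whole ((methoxycarbonyl)methyl)carbonyl group to the ring nitrogen gives a number 5.3 percentage points lower from compound 1 to compound 4 (within the scatter) and also stays inside the scatter, as does 1H-imidazol-1-yl in place of 4-methylpiperazin-1-yl, with a number 2.7 percentage points higher from compound 2 to compound 4 (within the scatter) on that aromatic carbon. No evidence on why these numbers stay so close is available. On these data alone, whether a carboxylic acid, an amine or a longer chain on this carbonyl carbon would move the read-out beyond the scatter remains open.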